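A few compounds are considered here, and "the series" means these few. Any claim that something is new, unique, unknown or untested is made for them only; others in the source may bear on it.

In an ADME assay on L02 cells (Homo sapiens) for cytotoxicity, read by MTT assay, with a stated time of 24 h (a higher number here means a weaker inhibitor, a lower number a stronger inhibitor), three compounds sharing one core have been measured. Compound 1 (`O=C1/C(=C/c2ccncc2)CN(S(=O)(=O)c2ccc(F)cc2)C/C1=C\c1ccccc1F`) gives 15600 nM, compound 2 (`O=C1/C(=C/c2cccnc2)CN(S(=O)(=O)c2ccccc2)C/C1=C\c1ccccc1C(F)(F)F`) gives 12500 nM, and compound 3 (`O=C1/C(=C/c2ccncc2)CN(S(=O)(=O)c2ccccc2)C/C1=C\c1ccccc1C(F)(F)F`) gives 12300 nM. Compound 3 thus stands within the scatter of both others, and the three cannot be ranked. The next structure, compound 4 (`O=C1/C(=C/c2ccncc2)CN(S(=O)(=O)c2ccc(F)cc2)C/C1=C\c1ccccc1C(F)(F)F`), turns the phenylsulfonyl group of compound 3 into (4-fluorophenyl)sulfonyl: fluoro in place of hydrogen on an aromatic carbon. Among the measured compounds shown here, no measured step makes this exact change. For the measured compounds named here, the one measured step, a 1.0-fold lower number from compound 2 to compound 3 (0.01 log units; within the scatter), instead replaces pyridin-3-yl with pyridin-4-yl. Compound 3 also differs in more than this one place from compound 1, which already carries the (4-fluorophenyl)sulfonyl group, and compound 1 gives 15600 nM, within the scatter of compound 3. The data therefore offer no reason to expect a step beyond the scatter in this assay, nor a clear direction. The expected step is a 1.1-fold higher number from compound 3 to compound 4 (0.02 log units; within the scatter). For compound 4 the estimated value is 13000 nM, with an expected range of 7500 nM to 22000 nM.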

Compound 4, half-maximal inhibitory concentration: 12900 nM
Beside the measured number, compound 4's estimate is 1.0-fold (0.00 log units) above it; measured number inside the range.
By their numbers in this assay, from the lowest: compounds 3, 2, 4 and 1 (each within the scatter of the next).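

In this assay, fluoro in place of hydrogen on an aromatic carbon, para to a large group, can now be read directly: a 1.0-fold higher number from compound 3 to compound 4 (0.02 log units; within the scatter) shows that this change leaves the number within the scatter. With the (4-fluorophenyl)sulfonyl group held fixed, the other aromatic ring can also be read, and trifluoromethyl in place of fluoro gives a 1.2-fold lower number from compound 1 to compound 4 (0.08 log units; within the scatter), again within the scatter. No independent measurement bears on either step.

At these two places the compounds shown carry only hydrogen, fluoro or trifluoromethyl, so it remains open whether an amine or a carboxylic acid there would give a step beyond the scatter. On these data alone, it also remains open whether fluoro on another carbon of the phenylsulfonyl ring would give the same reading.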